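A few compounds are considered here, and "the series" means these few. Any claim that something is new, unique, unknown or untested is made for them only; others in the source may bear on it.

Within the data shown here, compound 1, with the structure `CC[C@@H](Nc1c(C#N)c(-c2ccc(-c3ccncc3C)cc2)nc2cnccc12)C(N)=O`, is one of three compounds measured in a physicochemical assay for lipophilicity, read by HPLC, at pH 7.5 (a higher number here means a more lipophilic compound, a lower number a more polar compound), and in that assay compound 1 gives 2. Compound 2, `CCOc1ccccc1-c1ccc(-c2nc(NC(C)C(=O)O)c3ccncc3n2)cc1`, gives 2.1 in this assay, and compound 3, `CC(C)(CC(N)=O)c1c(C#N)c(-c2ccc(Br)cc2)nc2cnccc12`, gives 2.1. The numbers for compound 2 and compound 3 each sit within the usual scatter of the number for compound 1, so the three measured compounds cannot be told apart on this read-out.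

Compound 4, `CC[C@@H](Nc1c(C#N)c(-c2ccc(-c3ccccc3C)cc2)nc2cnccc12)C(N)=O`, has not yet been measured. It differs from compound 1 in a single change: 2-methylphenyl in place of 3-methylpyridin-4-yl on an aromatic carbon. The group that leaves carries one hydrogen-bond acceptor in its six-membered aromatic ring, and the group that enters is a ring of carbon only with none. Among the measured compounds shown here, no step of this kind stands among the measured compounds, so the expectation rests on the structural change alone. Compound 4 is expected to give 3, within a range from 2.4 to 3.6. This amounts to an expected step of a number 1.00 log units higher from compound 1 to compound 4 (beyond the scatter), an increase beyond the usual scatter.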

Compound 4, distribution coefficient: 3
Beside the measured number, compound 4's estimate shows no gap at the digits printed; the measured number falls inside the stated range.
By their numbers in this assay, from the lowest: compounds 1, 2 and 3 (each within the scatter of the next); then compound 4.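

This is the first pair among the compounds shown that differs in one place, so it gives the first reading of a single change at this position. In this assay, 2-methylphenyl in place of 3-methylpyridin-4-yl, on an aromatic carbon para to a large group, gives a step of a number 1.00 log units higher from compound 1 to compound 4 (beyond the scatter). The ring nitrogen of the leaving group is the only difference in heavy atoms between the two groups, yet no measurement here explains the step.

On these data alone, this is a single pair, so it remains open whether the same exchange would give a similar step on a different core. Also open, as far as these compounds go, is what this assay would show with another group at this place, such as an unsubstituted phenyl ring or a morpholine.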